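Amide Chain Exchanged for a Urea on a Shared Core

The source may report more compounds than this note shows. Statements on the series, on what has been measured and on what is new or still open speak of the compounds shown alone.

Of the compounds shown here, three that share one core have been measured in a functional assay on HT-29 cells (Homo sapiens) for antiproliferative activity, read by sulforhodamine B assay, with a stated time of 48 h; a higher number here means a weaker inhibitor, a lower number a stronger inhibitor. Compound 1 `CCCC(=O)Nc1ccc(S(=O)(=O)Oc2ccccc2I)cc1` gives 11000 nM, compound 2 `CCCCCC(=O)Nc1ccc(S(=O)(=O)Oc2ccccc2I)cc1` gives 13000 nM, and compound 3 `O=C(CCCCl)Nc1ccc(S(=O)(=O)Oc2ccccc2I)cc1` gives 9100 nM. Compound 3 sits at one end of this small set, but only just: the step of a 1.2-fold lower number from compound 1 to compound 3 (0.08 log units; within the scatter) and the step of a 1.4-fold lower number from compound 2 to compound 3 (0.15 log units; within the scatter) both stay inside the scatter of repeated measurements, as does the step of a 1.2-fold higher number from compound 1 to compound 2 (0.07 log units; within the scatter). The three measured compounds therefore behave alike.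

Compound 4 `CCNC(=O)Nc1ccc(S(=O)(=O)Oc2ccccc2I)cc1` has not been measured. It differs from compound 3 in one place: ethylamino in place of 3-chloropropyl on a carbonyl carbon. Each measured step swapped a group on a saturated chain carbon three bonds along the chain from a carbonyl carbon, and none moved the number beyond the scatter. Going by the values given here, the change to compound 4 acts on the carbonyl carbon itself and brings in a hydrogen-bond donor, which no measured step did, so the evidence is thinner. A step no larger than the scatter is expected in this assay, with no firm direction. For compound 4 the estimate is 12000 nM, with a range from 4000 nM to 35000 nM. This expectation amounts to a step of a 1.3-fold higher number from compound 3 to compound 4 (0.12 log units; within the scatter).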

Compound 4, half-maximal inhibitory concentration: 5300 nM
For compound 4 the middle estimate is 2.3-fold (0.35 log units) above the measured one; the range from low to high includes it.
By their numbers in this assay, from the lowest: compounds 4, 3, 1 and 2 (each within the scatter of the next, the first and the last beyond it).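

Putting ethylamino on the carbonyl carbon, which turns the amide into a urea and brings in a hydrogen-bond donor, is tolerated in this assay, and compound 4 gives up nothing against any of the three amides. Set against the plain chains, this change gives the only steps in the set that pass the scatter, both modest (a 2.5-fold lower number from compound 2 to compound 4 (0.39 log units; beyond the scatter) and a 2.1-fold lower number from compound 1 to compound 4 (0.32 log units; beyond the scatter)), while against the chlorinated chain it stays inside the scatter (a 1.7-fold lower number from compound 3 to compound 4 (0.23 log units; within the scatter)). No measurement is available that bears on the cause of these steps.

A dimethylamino group on the same carbonyl carbon would show whether the hydrogen on the new nitrogen matters. A longer chain on that nitrogen, such as butylamino or hexylamino, would show whether chain length stays as flat in the ureas as it does in the amides.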